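The compounds below may be only part of what the source reports. "The series", "measured", "known", "first", "only" and "open" are said of these compounds alone.

Compound 3 `CCCN(Cc1cccs1)C(=O)COc1ccc(C)cc1` stands second highest of the three numbers in an assay on HEK293 cells for agonist activity at transient receptor potential cation channel subfamily M member 8 (Homo sapiens), read by fluorescence and calcium flux, with a stated time of 15 min (a higher number here means that more compound is needed for the effect, a lower number that less compound is needed), giving 40 nM; compound 2 `Cc1ccc(OCC(=O)N(Cc2cccs2)c2ccon2)cc1` gives 2 nM and compound 1 `Cc1ccc(OCC(=O)N(Cc2cccs2)c2ccn(C)n2)cc1` gives 855 nM. Compound 4 `Cc1ccc(OCC(=O)N(Cc2cccs2)c2cn[nH]c2)cc1` differs from compound 3 in one place: 1H-pyrazol-4-yl in place of propyl on an amide-type nitrogen. Going by the values given here, two measured steps bear on this exchange, each setting propyl against a five-membered aromatic ring on the same amide-type nitrogen: a 20-fold higher number from compound 2 to compound 3 (1.30 log units; beyond the scatter) and a 21-fold lower number from compound 1 to compound 3 (1.33 log units; beyond the scatter). Read in reverse, a ring in place of propyl has moved this assay by a large step in either direction, so for compound 4 a step beyond the scatter is expected, though its direction cannot be fixed from these three compounds. The step expected is a 3.8-fold higher number from compound 3 to compound 4 (0.57 log units; beyond the scatter). Compound 4 is thus estimated at 150 nM, within a range from 10 nM to 2000 nM.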

Compound 4, half-maximal effective concentration: 1.4 nM
Estimate against measurement, compound 4: 110-fold (2.03 log units) above; the measured number lies below the stated range.
By their numbers in this assay, from the lowest: compounds 4 and 2 (each within the scatter of the next); then compound 3; then compound 1.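

With the 1H-pyrazol-4-yl ring on the amide-type nitrogen, this assay shows a 29-fold lower number from compound 3 to compound 4 (1.46 log units; beyond the scatter), so a ring at this place can give a much lower number than propyl even though the ring of compound 1 gives a higher one. The exchange for 1,2-oxazol-3-yl gives a 1.4-fold lower number from compound 2 to compound 4 (0.15 log units; within the scatter), so these two rings cannot be told apart here. Two pyrazole rings also stand far apart, with a 610-fold lower number from compound 1 to compound 4 (2.79 log units; beyond the scatter).

These compounds cannot separate the methyl group of compound 1 from the ring's point of attachment, so a 1-methyl-1H-pyrazol-4-yl group remains an open case. Nothing given here offers a reason for these steps.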